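The source may report more compounds than this note shows. Statements on the series, on what has been measured and on what is new or still open speak of the compounds shown alone.

Compound 1 `O/N=C(/Nc1ccccc1)c1ccc2occc2c1` is the starting point. In an assay on isolated protein for inhibition of Indoleamine 2,3-dioxygenase 1 (Homo sapiens), read by spectrophotometry (a lower number here means a stronger inhibitor, a higher number a weaker inhibitor), compound 1 gives > 30000 nM, which is a limit of the assay rather than a number. Compound 2 `O=C(NCC1CCCCC1)c1cccc(N/C(=N/O)c2ccc3occc3c2)c1` gives > 30000 nM, likewise a limit. Compound 3 `O=C(NCc1ccccc1)c1cccc(N/C(=N/O)c2ccc3occc3c2)c1` gives > 30000 nM, also a limit. The step that the two limits leave unreadable from compound 2 to compound 3 therefore cannot be sized. Compound 4 `O/N=C(/Nc1cccc(COc2ccccc2)c1)c1ccc2occc2c1` differs from compound 1 by phenoxymethyl in place of hydrogen on an aromatic carbon. Among the measured compounds shown here, no measured step bears on this change, since every value so far sits at the limit of > 30000 nM in this assay, at which 3 of the 3 values shown sit, so nothing shows whether adding a group of this kind helps or hurts. Compound 4 is accordingly expected to give 30000 nM, within a range of 6000 nM to 100000 nM. The step of a number no higher from compound 1 to compound 4 (the limit leaves the size open) is expected to be none beyond the scatter.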

Compound 4, half-maximal inhibitory concentration: > 30000 nM
Compound 4 was reported as a limit; the forecaster's own chance of this, stated with the estimate: 75%; the middle value lies on the limit itself.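

Among the compounds shown here, compound 1 and compound 4 are both reported only as limits of the assay, so no step between them can be read. The compounds shown leave open which change, if any, would bring a readable value, because all of them sit at the same limit: the limit of > 30000 nM in this assay, at which 4 of the 4 values shown sit.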